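The compounds below may be only part of what the source reports. "The series", "measured", "known", "first", "only" and "open" are said of these compounds alone.

Measured so far in a physicochemical assay for solubility, in phosphate buffer; a lower number here means a less soluble compound, a higher number a more soluble compound:
- compound 1, `CC(=O)c1ccc(Nc2ccnc(-c3cccnc3)n2)cc1`: 98000 nM
- compound 2, `CC(=O)c1cccc(Nc2ccnc(-c3cccnc3)n2)c1`: 97000 nM
- compound 3, `CC(=O)c1ccc(Nc2cc(C)nc(-c3cccnc3)n2)cc1`: 94000 nM

Compound 2 carries the same atoms as compound 1, joined differently; how the two cores differ is not broken down here. In this assay the values of compound 1 and compound 2 lie within the scatter of each other, and so do the values of compound 2 and compound 3.

Compound 3 is compound 1 with methyl in place of hydrogen on an aromatic carbon. The step is a 1.0-fold lower number from compound 1 to compound 3 (0.02 log units; within the scatter).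

Compound 4, `CC(=O)c1cccc(Nc2cc(C)nc(-c3cccnc3)n2)c1`, is not yet measured. It stands to compound 2 as compound 3 stands to compound 1: methyl in place of hydrogen on an aromatic carbon. The place of the change reads the same in both pairs, so this is the same change, made on the other core.

Expectation: because a 1.0-fold lower number from compound 1 to compound 3 (0.02 log units; within the scatter) stayed within the scatter, the step from compound 2 to compound 4 in this assay is expected to be a 1.0-fold lower number from compound 2 to compound 4 (0.01 log units; within the scatter). Compound 4 is estimated at 94000 nM, with a likely range from 50000 nM to 180000 nM. This rests on a single measured step, in a pair of cores whose difference is not broken down here.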

Compound 4, solubility: 95000 nM
Compound 4: the middle estimate sits 1.0-fold (0.00 log units) below what was measured; the range from low to high includes it.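

In this assay, methyl in place of hydrogen on an aromatic carbon gives a 1.0-fold lower number from compound 2 to compound 4 (0.01 log units; within the scatter), matching the within-scatter result on the other core, a 1.0-fold lower number from compound 1 to compound 3 (0.02 log units; within the scatter). The absence of a measurable step therefore carries between these two cores, but this is a single pair of cores and one place on the ring, and it does not show that the same would hold on a further core or at another place. No measurement shown here bears on why the step stays within the scatter on both cores.

Going by these compounds, it remains open whether a group other than methyl on the same aromatic carbon, such as an amine, a carboxylic acid or a longer chain, would give a step beyond the scatter on either core. Also open, on these data alone, is whether a step beyond the scatter on one core would carry over to the other, and these two steps do not test that.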